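The source may hold more compounds than are shown below. What is called first, only, known or untested is meant among the compounds shown, and "the series" means these compounds.

Compound 1 `CCC(C)n1cnc2c(N(C)C)ncnc21`: 14 mg/kg
Compound 2 `CC(C)Cn1cnc2c(N(C)C)ncnc21`: 5 mg/kg
Compound 3 `CCC(C)n1cnc2c(NC3CC3)ncnc21`: 13.5 mg/kg

All three were tested in a functional assay on the whole organism for antagonist activity, with Rattus norvegicus as the target; on this read-out higher numbers stand for an effect only at larger amounts of compound and lower numbers for an effect already at smaller amounts. Compound 1 and compound 3 differ by cyclopropylamino in place of dimethylamino on an aromatic carbon, and their numbers in this assay lie within the usual scatter of each other. Compound 2 differs from compound 1 by isobutyl in place of sec-butyl on an aromatic nitrogen, which brought a 2.8-fold lower number from compound 1 to compound 2 (0.45 log units; beyond the scatter).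

Compound 4 `CC(C)Cn1cnc2c(NC3CC3)ncnc21` has not yet been measured. Among the measured compounds shown here, it differs from compound 3 by isobutyl in place of sec-butyl on an aromatic nitrogen, the same change at the same place as the one from compound 1 to compound 2. Because compound 3 gives 13.5 mg/kg, and because the earlier step was a 2.8-fold lower number from compound 1 to compound 2 (0.45 log units; beyond the scatter), a step of about the same size is expected here. The expected step is a 2.8-fold lower number from compound 3 to compound 4 (0.45 log units; beyond the scatter). Compound 4 is therefore estimated to give 4.8 mg/kg, most likely between 2.5 mg/kg and 9.5 mg/kg. This rests on a single earlier example of the change.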

Compound 4, dose for half-maximal effect: 10 mg/kg
Compound 4: middle estimate off by 2.1-fold (0.32 log units), on the low side, outside the stated range (above it).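

In this assay, isobutyl in place of sec-butyl gave a 1.4-fold lower number from compound 3 to compound 4 (0.13 log units; within the scatter), and set beside the earlier example, this does not separate the two cores: the same change on two cores in this assay, a 2.8-fold lower number (0.45 log units; beyond the scatter) from compound 1 to compound 2 and a 1.4-fold lower number (0.13 log units; within the scatter) from compound 3 to compound 4, 2.1-fold (0.32 log units) apart, within the scatter of two such steps

Cyclopropylamino in place of dimethylamino gave a 2.0-fold higher number from compound 2 to compound 4 (0.30 log units; within the scatter), and this change does not separate the cores either: the same change on two cores in this assay, a 1.0-fold lower number (0.02 log units; within the scatter) from compound 1 to compound 3 and a 2.0-fold higher number (0.30 log units; within the scatter) from compound 2 to compound 4, 2.1-fold (0.32 log units) apart, within the scatter of two such steps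

So neither change shows a firm dependence on the core it is made on, but two examples of each, with steps this close to the scatter, do not prove that either carries over unaltered.

On these data alone, it remains open how a longer chain or a benzyl group on the aromatic nitrogen, or a primary amine on the aromatic carbon, would behave.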